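Swapping fluoro for methylsulfanyl in the lowest-exposure compound

The source may report more compounds than this note shows. Statements on the series, on what has been measured and on what is new or still open speak of the compounds shown alone.

Compound 1 `CSc1ccc(C2=C(c3ccc(C)cc3)C(=O)N3CCCC3C2)cc1`: 13500 ng.h/mL
Compound 2 `CSc1ccc(C2=C(c3ccc(C(F)(F)F)cc3)C(=O)N3CCCC3C2)cc1`: 4330 ng.h/mL
Compound 3 `CSc1ccc(C2=C(c3ccc(F)cc3)C(=O)N3CCCC3C2)cc1`: 1370 ng.h/mL

These values all come from an ADME assay on the whole organism with Mus musculus as the target, at a dose of 200 mg/kg by the intraperitoneal route (on this read-out higher numbers stand for higher exposure at the dose given and lower numbers for lower exposure), and, among them, compound 3 at 1370 ng.h/mL is the lowest, with its steps to both other compounds beyond the scatter. The next compound, compound 4 `CSc1ccc(C2=C(c3ccc(SC)cc3)C(=O)N3CCCC3C2)cc1`, differs from it in one place: methylsulfanyl in place of fluoro on an aromatic carbon, which is methylsulfanyl in place of fluoro on an aromatic carbon.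

The three measured steps all concern that same place. Two of them end at fluoro: a 9.9-fold lower number from compound 1 to compound 3 (0.99 log units; beyond the scatter) and a 3.2-fold lower number from compound 2 to compound 3 (0.50 log units; beyond the scatter). The third, a 3.1-fold lower number from compound 1 to compound 2 (0.49 log units; beyond the scatter), shows that the two non-fluoro groups also differ from each other. Each step is modest but beyond the scatter. Going by the values given here, in these three compounds, fluoro gives the lowest number and none goes against that, but no measured compound yet carries methylsulfanyl at this place. A rise in this assay of similar size to these steps is therefore expected, with wide uncertainty. The expected change is a 3.6-fold higher number from compound 3 to compound 4 (0.56 log units; beyond the scatter) as an estimate. For compound 4 the estimated value is 5000 ng.h/mL, with an expected range from 1500 ng.h/mL to 16000 ng.h/mL.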

Compound 4, area under the concentration-time curve: 954 ng.h/mL
Compound 4: the middle estimate sits 5.2-fold (0.72 log units) above what was measured, and the stated range ends above it.
By their numbers in this assay, from the lowest: compounds 4 and 3 (each within the scatter of the next); then compound 2; then compound 1.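

In this assay, methylsulfanyl on this aromatic carbon, para to a large group, leaves the number at the level seen with fluoro, with a 1.4-fold lower number from compound 3 to compound 4 (0.16 log units; within the scatter). Set against the other two groups, it gives a 4.5-fold lower number from compound 2 to compound 4 (0.66 log units; beyond the scatter) and a 14-fold lower number from compound 1 to compound 4 (1.15 log units; beyond the scatter), so the low end of the series now holds two different groups, fluoro and methylsulfanyl, while trifluoromethyl and methyl stand higher. Fluoro alone therefore does not mark the low end at this position, but nothing shown here explains why the four groups fall in this order.

From the compounds shown here alone, it remains open whether the high number with methyl is particular to that small group or would carry over to a longer chain such as ethyl, and whether an amine or a carboxylic acid at this place would fall outside the range of the four groups seen. Also open, going by these compounds, is whether the same order would hold if the other methylsulfanyl, which is the same in all four compounds, were replaced.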